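The source may hold more compounds than are shown below. What is called first, only, known or untested is meant among the compounds shown, and "the series" means these compounds.

Measured in a functional assay on MCF7 cells (Homo sapiens) for inhibition, read by sulforhodamine B assay, with a stated time of 72 h (a higher number here means a weaker inhibitor of growth, a lower number a stronger inhibitor of growth), so far
- Compound 1 `CNC(=O)/C=C/c1ccncc1-c1ccc2ccccc2c1` gives 9340 nM
- Compound 2 `CCOC(=O)/C=C/c1ccncc1-c1ccc2c(cnn2C)c1` gives 7320 nM
- Compound 3 `CNC(=O)/C=C/c1ccncc1-c1ccc2cc[nH]c2c1` gives 9230 nM

Compound 3 lies within the usual scatter of both compound 1 and compound 2, so these numbers do not separate the three compounds. Compound 4 `CCOC(=O)/C=C/c1ccncc1-c1ccc2cc[nH]c2c1` has ethoxy in place of methylamino on a carbonyl carbon, which turns the methylcarbamoyl group into ethoxycarbonyl. Within the data shown here, no measured pair isolates this change, so the evidence is indirect. Compound 2 has a different core but already carries 2-(ethoxycarbonyl)ethenyl, and it gives 7320 nM in this assay without leaving the scatter of the other two. The expected step of a 1.2-fold lower number from compound 3 to compound 4 (0.07 log units; within the scatter) is therefore no larger than the scatter. For compound 4 the estimated value is 7800 nM with an expected range from 3800 nM to 15000 nM in this measurement.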

Compound 4, concentration for 50% growth inhibition: 6880 nM
Compound 4: the middle estimate sits 1.1-fold (0.05 log units) above what was measured, and the stated range covers the measured number.
By their numbers in this assay, from the lowest: compounds 4, 2, 3 and 1 (each within the scatter of the next).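

Among these compounds, this is the first pair that differs in one place only: in this assay, ethoxy in place of methylamino on a carbonyl carbon gives a 1.3-fold lower number from compound 3 to compound 4 (0.13 log units; within the scatter). On this core, then, methylcarbamoyl and ethoxycarbonyl are not told apart, even though the hydrogen-bond donor of methylamino is gone in compound 4. No other measurement explains this result.

Still open, going by these compounds, is whether a carboxylic acid or a longer chain on this carbonyl carbon would give a number beyond the scatter. Whether the same swap behaves alike on the cores of compound 1 and compound 2 also cannot be read here.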